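A few compounds are considered here, and "the series" means these few. Any claim that something is new, unique, unknown or untested is made for them only; others in the source may bear on it.

Compound 1 `Cc1c(-c2cc(Cl)cc(Cl)c2)c(C(=O)O)nn1-c1nc(-c2cc(Cl)ccc2F)c(SC(C)C)s1` and compound 2 `Cc1ccccc1-c1c(C)nn(-c2nc(-c3ccc(Cl)c(Cl)c3)c(SC(C)C)s2)c1C(=O)O` share one core and differ in the rings attached to it. In a functional assay on BJAB cells (Homo sapiens) for antiproliferative activity, with a stated time of 4 days (a lower number here means that less compound is needed, a higher number that more compound is needed for the effect), compound 1 gives 4800 nM, and in this assay compound 2 gives 5500 nM; these two numbers lie within the usual scatter of each other, so compound 2 stands beside compound 1 rather than apart from it. Compound 3 `Cc1nn(-c2nc(-c3ccc(Cl)c(Cl)c3)c(SC(C)C)s2)c(C(=O)O)c1-c1cncc(C#N)c1` differs from compound 2 in one place: 5-cyanopyridin-3-yl in place of 2-methylphenyl on an aromatic carbon. Within the data shown here, no measured pair shows the effect of this change, so its direction is open. For compound 3 the expected value is 7000 nM, with a range from 2500 nM to 20000 nM. This is expected to be a step of a 1.3-fold higher number from compound 2 to compound 3 (0.10 log units; within the scatter), close to the scatter.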

Compound 3, half-maximal effective concentration: 20000 nM
The estimate for compound 3 lay 2.9-fold (0.46 log units) below the measured number; measured number inside the range.
By their numbers in this assay, from the lowest: compounds 1 and 2 (each within the scatter of the next); then compound 3.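

The aromatic carbon carrying this ring is not indifferent to what sits there: in this assay the change from 2-methylphenyl to 5-cyanopyridin-3-yl gives a 3.6-fold higher number from compound 2 to compound 3 (0.56 log units; beyond the scatter) and so more compound is needed for the effect. Nothing at hand explains this step.

This one change replaces the ring and adds a nitrile together, so the compounds shown cannot tell which part carries the step. A plain phenyl or an unsubstituted pyridin-3-yl at this place would help to separate the two.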